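Amide aryl variation: notes toward compound 3

The source may hold more compounds than are shown below. What is called first, only, known or untested is meant among the compounds shown, and "the series" means these compounds.

Compound 1 `COc1ccc(C(=O)Nc2cccc(-c3oc4cc(-c5ccc(F)cc5)ccc4c(=O)c3O)c2)cc1` and compound 2 `O=C(Nc1cccc(-c2oc3cc(-c4ccc(F)cc4)ccc3c(=O)c2O)c1)c1ccc(Br)cc1` share one core and differ only in the group on the ring attached to the carbonyl carbon. In a functional assay on HeLa cells (Homo sapiens) for antiproliferative activity, read by CCK-8 assay, with a stated time of 72 h (a higher number here means a weaker inhibitor, a lower number a stronger inhibitor), compound 1 gives 4820 nM, and compound 2 gives 9740 nM. The step of a 2.0-fold higher number from compound 1 to compound 2 (0.31 log units; beyond the scatter) is the only one measured so far, and it leaves compound 2 with the highest of the two numbers, compound 1 being the nearest. Compound 3 `O=C(Nc1cccc(-c2oc3cc(-c4ccc(F)cc4)ccc3c(=O)c2O)c1)c1cc(F)cc(F)c1` is not yet measured; it differs from compound 2 in that (3,5-difluorophenyl in place of 4-bromophenyl on a carbonyl carbon). Going by the values given here, no measured step covers a 3,5-difluorophenyl, so the expectation for compound 3 in this assay rests only on the step of a 2.0-fold higher number from compound 1 to compound 2 (0.31 log units; beyond the scatter), which shows that exchanging the group on this ring moves the number by a modest amount. A change of comparable size is expected for compound 3, in either direction, with no confident call beyond the scatter. For compound 3 the expected step is a 1.4-fold lower number from compound 2 to compound 3 (0.14 log units; within the scatter). For compound 3 the estimate in this assay is therefore 7000 nM, within a range from 2500 nM to 20000 nM.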

Compound 3, half-maximal inhibitory concentration: 3380 nM
Compound 3: middle estimate off by 2.1-fold (0.32 log units), on the high side; measured number inside the range.
By their numbers in this assay, from the lowest: compounds 3 and 1 (each within the scatter of the next); then compound 2.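

The exchange gives a 2.9-fold lower number from compound 2 to compound 3 (0.46 log units; beyond the scatter) in this assay and so shows that a halogen on this ring does not by itself go with the higher number: 4-bromophenyl and 3,5-difluorophenyl, both halogen-bearing, stand apart beyond the scatter. The same group set against 4-methoxyphenyl gives a 1.4-fold lower number from compound 1 to compound 3 (0.15 log units; within the scatter) and so does not separate these two groups, which leaves compound 2 as the weakest of the three and the only one that stands apart. No measurement is at hand that bears on why these groups differ.

The three groups leave open whether the step to 3,5-difluorophenyl follows from the kind of halogen, the number of halogens or their place on the ring, a question that 4-fluorophenyl or 3,5-dibromophenyl would help to pull apart. Also open, on these data alone, is how the number responds to groups of another kind on this carbonyl carbon, such as a phenyl ring bearing an amine or a carboxylic acid, or a saturated cyclohexyl ring in place of the aromatic one.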